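Rhodanine series: aryl swap on the ring nitrogen

The compounds below may be only part of what the source reports. "The series", "measured", "known", "first", "only" and "open" are said of these compounds alone.

Going by the values given here, compound 2 `O=C(O)c1ccc(COc2ccc(/C=C3\SC(=S)N(c4ccc(I)cc4)C3=O)cc2)cc1` gives 4300 nM in an assay on isolated protein for inhibition of Apoptosis regulator Bcl-2 (Homo sapiens), read by fluorescence polarization (a lower number here means a stronger inhibitor, a higher number a weaker inhibitor), and is the only number among the values shown. Compound 1 `CC(=O)c1ccc(N2C(=O)/C(=C/c3ccc(OCc4ccc(C(=O)O)cc4)cc3)SC2=S)cc1` returns only a limit of the assay, > 10000 nM. Among the compounds with values here, the one measured step, an at least 2.3-fold lower number from compound 1 to compound 2 (0.36 log units; beyond the scatter), is read against the limit of > 10000 nM in this assay, at which 1 of the 2 values shown sits, and so is a floor, not a size. Compound 3 `O=C(O)c1ccc(COc2ccc(/C=C3\SC(=S)N(c4c(F)cccc4F)C3=O)cc2)cc1` differs by 2,6-difluorophenyl in place of 4-iodophenyl on an amide-type nitrogen in a ring. Within the data shown here, no measured step covers such a change, so the direction of the step in this assay is undetermined. Compound 3 is estimated at 6000 nM, spanning 2000 nM to 20000 nM. This expected step, a 1.4-fold higher number from compound 2 to compound 3 (0.14 log units; within the scatter), is within the scatter.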

Compound 3, inhibition constant: > 10000 nM
Compound 3: only a limit was reported; the forecaster's own chance of this, stated with the estimate: 30%; middle value at least 1.6-fold (0.22 log units) from the limit.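

With an at least 2.3-fold higher number from compound 2 to compound 3 (0.36 log units; beyond the scatter), 2,6-difluorophenyl in place of 4-iodophenyl on the amide-type nitrogen in a ring gives a weaker result in this assay, so 4-iodophenyl is now better than both other aryl groups shown at this position. The step between compound 1 and compound 3 cannot be read, as both carry only limits. The step from compound 2 is therefore a floor, not a size: the limit of > 10000 nM in this assay, at which 2 of the 3 values shown sit.

On these data alone, how far compound 3 lies from compound 2 stays open. Also open, as far as these compounds go, is whether 4-bromophenyl or unsubstituted phenyl on this nitrogen would keep a measurable number.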